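This account rests on a few compounds, and the source may have more. Where it says the series, first, only, none or still open, it means among the compounds named here.

In an ADME assay on BV-2 cells (Mus musculus) for cytotoxicity, with a stated time of 24 h, tested at 50 uM (on this read-out higher numbers stand for a weaker effect at the one concentration tested and lower numbers for a stronger effect), compound 1, with the structure `COc1ccccc1S(=O)(=O)/C=C/c1ccncc1`, gives 78.9%. Compound 2, with the structure `COc1ccc(S(=O)(=O)/C=C/c2ccncc2)cc1`, gives 69% in this assay. The two share the same atoms joined differently, and the difference between their two cores is not broken down here. Their two values lie within the scatter of each other. Compound 3, with the structure `COc1ccccc1S(=O)(=O)/C=C/c1cncnc1`, gives 97.9% in this assay. Against compound 1 it carries one change, (pyrimidin-5-yl in place of pyridin-4-yl on a double-bonded chain carbon bound to a double-bonded chain carbon), and that change made the step of a number 19 percentage points higher from compound 1 to compound 3 (beyond the scatter). Compound 2 and compound 3 differ by a gap beyond the scatter, as their two values show.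

Compound 4, with the structure `COc1ccc(S(=O)(=O)/C=C/c2cncnc2)cc1`, is not yet measured. It differs from compound 2 by pyrimidin-5-yl in place of pyridin-4-yl on a double-bonded chain carbon bound to a double-bonded chain carbon, at the same place as before, so this is the same change as that from compound 1 to compound 3. Among the compounds with values here, for compound 4 a step of a number 17 percentage points higher from compound 2 to compound 4 (beyond the scatter) is expected, set beside a number 19 percentage points higher from compound 1 to compound 3 (beyond the scatter), the only earlier step known for this change. The starting point of this expectation is compound 2 with its value 69%. On that basis the value of compound 4 in this assay is estimated at 86%, expected to fall between 73% and 99%.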

Compound 4, a percentage reported as activity, at one concentration (the size of the read-out at that concentration, not a potency): 100%
The estimate for compound 4 lay 14 percentage points below the measured number, outside the stated range (above it).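

In this assay, pyrimidin-5-yl in place of pyridin-4-yl on a double-bonded chain carbon gives a step of a number 31 percentage points higher from compound 2 to compound 4 (beyond the scatter), and this agrees in direction with the step already seen on the other core, with no size difference that can be told from the usual variation: the same change on two cores in this assay, a number 19 percentage points higher (beyond the scatter) from compound 1 to compound 3 and a number 31 percentage points higher (beyond the scatter) from compound 2 to compound 4, 12 percentage points apart, within the scatter of two such steps. On these two cores, then, the change carries over: it moves the read-out the same way on both, and the data give no ground for saying that the core alters the size of the step. Within the data shown here, this does not show that the change would behave in the same way on a third core, as the evidence rests on only two matched pairs, and it says nothing about why the number rises.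

The compounds shown leave open how the read-out would respond if an amine or a carboxylic acid stood at this place instead of either ring. They also leave open what a longer chain would do in place of the double-bonded chain on either core.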